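Carboxylate variants on the benzylamino substituent

The source may hold more compounds than are shown below. What is called first, only, known or untested is meant among the compounds shown, and "the series" means these compounds.

Measured so far:
compound 1 `Nc1cccc(CNc2cc(C(F)(F)F)cc3[nH]ncc23)c1` gives 2510 nM in an assay for inhibition of Tryptophan 2,3-dioxygenase (Homo sapiens), with stated times of 10 min and 60 min; a higher number here means a weaker inhibitor, a lower number a stronger inhibitor
compound 2 `O=[N+]([O-])c1cccc(CNc2cc(C(F)(F)F)cc3[nH]ncc23)c1` gives 5170 nM
compound 3 `O=C(O)CNc1cccc(CNc2cc(C(F)(F)F)cc3[nH]ncc23)c1` gives > 100000 nM

The value for compound 3 is a limit of the assay, not a number; it sits at the limit of > 100000 nM in this assay, at which 1 of the 3 values shown sits, the weakest position among the three. The step of an at least 39-fold higher number from compound 1 to compound 3 (1.60 log units; beyond the scatter) and the step of an at least 19-fold higher number from compound 2 to compound 3 (1.28 log units; beyond the scatter) both run from a measured number up to that limit. Compound 4 `O=C(O)c1cccc(CNc2cc(C(F)(F)F)cc3[nH]ncc23)c1` differs from compound 3 by carboxy in place of (carboxymethyl)amino on an aromatic carbon. Both measured steps that bear on it involve placing a carboxy-bearing group on this ring and were large losses, so a weak result is expected for compound 4, with the step of an at least 1.2-fold lower number from compound 3 to compound 4 (0.09 log units; that floor lies within the scatter) taken from a limit and therefore uncertain. Compound 4 is expected to give about 80000 nM, between 15000 nM and 300000 nM, in this assay.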

Compound 4, half-maximal inhibitory concentration: 1690 nM
Estimate against measurement, compound 4: 47-fold (1.68 log units) above; measured number outside the range, below it.
By their numbers in this assay, from the lowest: compounds 4 and 1 (each within the scatter of the next); then compound 2. At a limit, above all of these: compound 3.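

Carboxy on this aromatic carbon is tolerated in this assay: a 1.5-fold lower number from compound 1 to compound 4 (0.17 log units; within the scatter), and a 3.1-fold lower number from compound 2 to compound 4 (0.49 log units; beyond the scatter). The large loss seen earlier therefore goes with (carboxymethyl)amino, not with every carboxy-bearing group on this ring: an at least 59-fold lower number from compound 3 to compound 4 (1.77 log units; beyond the scatter). The value of compound 3 is a limit of the assay, not a number: the limit of > 100000 nM in this assay, at which 1 of the 4 values shown sits.

Still open, on these data alone, is whether that loss follows the chain length or the nitrogen within the chain. A carboxymethyl group without the nitrogen, a longer chain ending in a carboxylic acid, and a methyl ester or primary amide in place of carboxy would separate these.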